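Amide aryl exchange in compound 4 against two limits

The source may hold more compounds than are shown below. What is called first, only, known or untested is meant among the compounds shown, and "the series" means these compounds.

Compound 3 `O=C(COc1ccc2cc(/C=C3/SC(=O)NC3=O)ccc2c1)Nc1cc(Cl)cc(C(F)(F)F)c1` carries a 3-chloro-5-(trifluoromethyl)phenyl on the amide-type nitrogen of the shared core. In an assay on isolated protein for inhibition of histone deacetylase 8 (Homo sapiens), with a stated time of 1 h (on this read-out lower numbers stand for stronger inhibition and higher numbers for weaker inhibition), compound 3 returns only a limit, > 50000 nM, not a number. Compound 2 `Cc1ccc(NC(=O)COc2ccc3cc(/C=C4/SC(=O)NC4=O)ccc3c2)cc1Cl` likewise stops at a limit in this assay, > 50000 nM. Among the measured compounds shown here, compound 1 `Cc1ccc(NC(=O)COc2ccc3cc(/C=C4/SC(=O)NC4=O)ccc3c2)cc1`, with the 4-methylphenyl, is the one member with a read number: 9000 nM in this assay. The measured steps bearing on an aryl exchange at this position are an at least 5.5-fold higher number from compound 1 to compound 3 (0.74 log units; beyond the scatter) and, for a single chloro added to that ring, an at least 5.5-fold higher number from compound 1 to compound 2 (0.74 log units; beyond the scatter); the third, a step that the two limits leave unreadable from compound 2 to compound 3, cannot be sized, since compound 2 and compound 3 both sit at the limit of > 50000 nM in this assay, at which 2 of the 3 values shown sit.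

Compound 4 `O=C(COc1ccc2cc(/C=C3/SC(=O)NC3=O)ccc2c1)Nc1ccc(Br)cc1F` introduces (4-bromo-2-fluorophenyl in place of 3-chloro-5-(trifluoromethyl)phenyl on an amide-type nitrogen). Both halogen-bearing anilides measured so far ended at the limit, and compound 4 keeps halogens on that ring; there is no measured case of a dihalophenyl recovering the number seen for compound 1. The expectation is that compound 4 again lands at or close to the limit in this assay, with an estimate of 40000 nM spanning 9000 nM to 150000 nM. The step this estimate implies, an at least 1.2-fold lower number from compound 3 to compound 4 (0.09 log units; that floor lies within the scatter), is expected to be unreadable against the limit of compound 3.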

Compound 4, half-maximal inhibitory concentration: > 50000 nM
Compound 4: a limit, no number; the forecaster's own chance of this, stated with the estimate: 65%; middle value at least 1.2-fold (0.09 log units) from the limit.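

In this assay compound 4 also returns only a limit, > 50000 nM, not a number. The one readable step is an at least 5.5-fold higher number from compound 1 to compound 4 (0.74 log units; beyond the scatter), so a third halogen-bearing aryl on the amide-type nitrogen, here the 4-bromo-2-fluorophenyl with no trifluoromethyl, gives no read number, and among the compounds shown none goes against the split between the 4-methylphenyl of compound 1 and the halogen-bearing aryls. The steps from compound 2 and from compound 3 to compound 4 cannot be read, since both ends of each are limits, and the position now stands with a single read number against a shared limit: the limit of > 50000 nM in this assay, at which 3 of the 4 values shown sit.

With only compound 1 lacking halogen, the compounds shown cannot separate an effect of halogen on the ring from an effect of any departure from the 4-methylphenyl. Also open, from the compounds shown here alone, is whether an unsubstituted phenyl, or an aryl carrying an amine, a methoxy or a carboxylic acid in place of the halogens, would give a read number in this assay.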